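The source may hold more compounds than are shown below. What is called first, only, known or untested is meant among the compounds shown, and "the series" means these compounds.

Measured in a functional assay on A549 cells (Homo sapiens) for inhibition, read by MTT assay, with a stated time of 24 h; a higher number here means a weaker inhibitor of growth, a lower number a stronger inhibitor of growth:
- compound 1 `COc1ccccc1C(=O)n1c(-c2cn(C)c3ccccc23)nc2ccccc21`: 12300 nM
- compound 2 `COc1ccc(C(=O)n2c(-c3cn(C)c4ccccc34)nc3ccccc32)cc1OC`: 3100 nM

Within the data shown here, compound 2 holds the lower of the two numbers, and the only measured step is a 4.0-fold lower number from compound 1 to compound 2 (0.60 log units; beyond the scatter). That step places 3,4-dimethoxyphenyl in place of 2-methoxyphenyl on a carbonyl carbon.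

Compound 3 `Cn1cc(-c2nc3ccccc3n2C(=O)c2ccccc2Br)c2ccccc21` has not yet been measured. Its change from compound 2 is 2-bromophenyl in place of 3,4-dimethoxyphenyl on a carbonyl carbon, which is 2-bromophenyl in place of 3,4-dimethoxyphenyl on a carbonyl carbon.

Among the measured compounds shown here, the one measured step bears on this change read in reverse: 3,4-dimethoxyphenyl leaves, and the entering 2-bromophenyl is the closer match by name to the 2-methoxyphenyl of compound 1. For the measured compounds named here, no measured compound carries bromine, so this comparison is thin. A rise of modest size in this assay is expected, resting on a 4.0-fold lower number from compound 1 to compound 2 (0.60 log units; beyond the scatter) and not exceeding it by much.

The estimated step is a 2.9-fold higher number from compound 2 to compound 3 (0.46 log units; beyond the scatter). For compound 3 the expected value is 9000 nM, with an estimated range of 3000 nM to 27000 nM.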

Compound 3, concentration for 50% growth inhibition: 43200 nM
Compound 3: middle estimate off by 4.8-fold (0.68 log units), on the low side; the whole stated range lies below it.
By their numbers in this assay, from the lowest: compound 2; then compound 1; then compound 3.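

In this assay, among these compounds, the group on the carbonyl carbon now proves able to move the number by a large amount: 2-bromophenyl in place of 3,4-dimethoxyphenyl gives a 14-fold higher number from compound 2 to compound 3 (1.14 log units; beyond the scatter), a wider spread at this position than the earlier compounds showed. The second new comparison isolates a smaller change, bromo in place of methoxy on an aromatic carbon, and gives a 3.5-fold higher number from compound 1 to compound 3 (0.55 log units; beyond the scatter), so this one exchange on the phenyl group is enough to raise the number by a modest step beyond the scatter, and among these three compounds the 3,4-dimethoxyphenyl group of compound 2 keeps the lowest number. Nothing measured here offers an explanation for either step.

Going by these compounds, it remains open which of the two methoxy groups of the 3,4-dimethoxyphenyl group accounts for the lower number of compound 2, or whether both are needed. On these data alone, it is also open where other groups on the phenyl ring would fall relative to bromo and methoxy, for example chloro, an amine or a carboxylic acid.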